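Changing the Group on the Carbonyl Carbon of Compound 2

A few compounds are considered here, and "the series" means these few. Any claim that something is new, unique, unknown or untested is made for them only; others in the source may bear on it.

Among the measured compounds shown here, in a functional assay on isolated protein for inhibition of Glucose-dependent insulinotropic receptor (Rattus norvegicus), read by HTRF and cAMP accumulation (a lower number here means that less compound is needed, a higher number that more compound is needed for the effect), compound 2 `Cc1nc(S(C)(=O)=O)ccc1Oc1ncnc(OC2CCN(C(=O)SC3(C)CC3)CC2)c1F` gives 166 nM, the higher of the two numbers so far, though only within the scatter of its one neighbour. Compound 1 `Cc1nc(S(C)(=O)=O)ccc1Oc1ncnc(OC2CCN(C(=O)OC(C)C)CC2)c1F` gives 142 nM in this assay. For the measured compounds named here, the single step measured so far, a 1.2-fold higher number from compound 1 to compound 2 (0.07 log units; within the scatter), stayed within the scatter. Compound 3 `Cc1nc(S(C)(=O)=O)ccc1Oc1ncnc(OC2CCN(C(=O)c3noc(C(C)C)n3)CC2)c1F` differs from compound 2 by a group of 8 heavy atoms (5 carbon, 2 nitrogen, 1 oxygen; one five-membered aromatic ring with 3 hetero atoms) in place of a group of 5 heavy atoms (4 carbon, 1 sulfur; one three-membered non-aromatic ring of carbon only), on a carbonyl carbon. This change sits on the same carbonyl carbon as the earlier step, which barely moved the number, so little shift beyond the scatter is expected. The estimated value for compound 3 is 150 nM, between 50 nM and 450 nM. That amounts to an expected step of a 1.1-fold lower number from compound 2 to compound 3 (0.04 log units; within the scatter).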

Compound 3, half-maximal effective concentration: 176 nM
Compound 3: middle estimate off by 1.2-fold (0.07 log units), on the low side; the range from low to high includes it.
By their numbers in this assay, from the lowest: compounds 1, 2 and 3 (each within the scatter of the next).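

In this assay swapping the sulfur-bearing group on the carbonyl carbon for 5-isopropyl-1,2,4-oxadiazol-3-yl gives a 1.1-fold higher number from compound 2 to compound 3 (0.03 log units; within the scatter) and swapping isopropoxy for it gives a 1.2-fold higher number from compound 1 to compound 3 (0.09 log units; within the scatter) as well. Until now this carbonyl carbon carried only groups joined through oxygen or sulfur, and a group joined through a carbon of an aromatic ring now stands there with no step beyond the scatter.

On these data alone, whether an amine or a plain methyl group on this carbonyl carbon would shift the number beyond the scatter remains open. No outside data bear on this result.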